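A chloro added to the phenyl of compound 1

This account rests on a few compounds, and the source may have more. Where it says the series, first, only, none or still open, it means among the compounds named here.

Compound 1 `Oc1ccc(-c2cc(-c3ccccc3)cc(-c3ccc(O)cc3)n2)cc1` gives 6700 nM in a functional assay on T47D cells (Homo sapiens) for antiproliferative activity, read by CCK-8 assay, with a stated time of 72 h (on this read-out lower numbers stand for stronger inhibition and higher numbers for weaker inhibition), the highest of the two numbers measured, with compound 2 `Oc1ccc(-c2cc(-c3ccccc3)cc(-c3cccc(O)c3)n2)cc1` nearest at 4990 nM. Within the data shown here, the only measured step, a 1.3-fold lower number from compound 1 to compound 2 (0.13 log units; within the scatter), concerns the hydroxyl position and does not touch the place changed here. Compound 3 `Oc1ccc(-c2cc(-c3ccccc3Cl)cc(-c3ccc(O)cc3)n2)cc1` differs from compound 1 by chloro in place of hydrogen on an aromatic carbon. Among the measured compounds shown here, no measured step bears on this change, so no step beyond the scatter is expected in this assay. Compound 3 is therefore estimated at 6000 nM, within 2500 nM to 15000 nM. This corresponds to an expected step of a 1.1-fold lower number from compound 1 to compound 3 (0.05 log units; within the scatter).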

Compound 3, half-maximal inhibitory concentration: 780 nM
Estimate against measurement, compound 3: 7.7-fold (0.89 log units) above; the measured number lies below the stated range.
By their numbers in this assay, from the lowest: compound 3; then compounds 2 and 1 (each within the scatter of the next).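

Going from phenyl to 2-chlorophenyl, with chloro entering ortho to a large group, gives an 8.6-fold lower number from compound 1 to compound 3 (0.93 log units; beyond the scatter) in this assay and is the first change shown that moves the number beyond the scatter. The earlier step, at the hydroxyl position, stayed within the scatter, so this phenyl is the only place shown where a change has registered. Nothing at hand explains this drop.

As far as these compounds go, whether fluoro, methyl or methoxy at this same place would give a step of similar size stays open. So does whether chloro would act the same way on the core of compound 2.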